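Aryl replacement on the shared core: expectation for compound 4

The compounds below may be only part of what the source reports. "The series", "measured", "known", "first", "only" and "open" are said of these compounds alone.

In a functional assay on KB cells (Homo sapiens) for antiproliferative activity, read by sulforhodamine B assay, with a stated time of 3 days (a lower number here means that less compound is needed, a higher number that more compound is needed for the effect), compound 1 `CCC1=C(O)c2c(oc(-c3ccc(O)cc3)cc2=O)C(CC)(CC)C1=O` gives 20.6 uM, the lowest of the two numbers at hand. Compound 3 `CCC1=C(O)c2c(oc(-c3ccccc3C(F)(F)F)cc2=O)C(CC)(CC)C1=O` gives 45.6 uM in this assay, a step from compound 1 that lies beyond the scatter. Compound 2 `CCC1=C(O)c2c(oc(-c3cccc(OC(F)(F)F)c3)cc2=O)C(CC)(CC)C1=O` returns only a limit of the assay in this assay, > 47.4 uM, not a number; the relevant reading is the limit of > 47.4 uM in this assay, at which 1 of the 3 values shown sits. Compound 4 `CCC1=C(O)c2c(oc(-c3ccc(C)cc3C)cc2=O)C(CC)(CC)C1=O` has not been measured. It differs from compound 1 by 2,4-dimethylphenyl in place of 4-hydroxyphenyl on an aromatic carbon. Among the measured compounds shown here, no measured pair covers this exact change; the two aryl variants without a hydroxyl both sit higher than compound 1. Compound 4 is therefore expected to give 40 uM, between 15 uM and 90 uM, in this assay. The expected step is a 1.9-fold higher number from compound 1 to compound 4 (0.29 log units; within the scatter), toward a higher number.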

Compound 4, concentration for half-maximal effect: 41.2 uM
Estimate against measurement, compound 4: 1.0-fold (0.01 log units) below, and the stated range covers the measured number.
By their numbers in this assay, from the lowest: compounds 1, 4 and 3 (each within the scatter of the next, the first and the last beyond it). At a limit, above all of these: compound 2.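

In this assay, 2,4-dimethylphenyl in place of 4-hydroxyphenyl gives a 2.0-fold higher number from compound 1 to compound 4 (0.30 log units; within the scatter) and so does not separate the two compounds, although the entering group counts no hydrogen-bond donor or acceptor. At this aromatic carbon, the hydroxyl of the aryl group is therefore not shown to be needed for a number of this size. No measured property bears on this step.

As far as these compounds go, whether an amine or a carboxylic acid on the aryl ring would move the number stays open. So does the effect of a longer chain in place of either methyl.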